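This account rests on a few compounds, and the source may have more. Where it says the series, first, only, none or still open, it means among the compounds named here.

Compound 1 `O=C(NNc1ccccc1Cl)c1ccccc1NS(=O)(=O)c1cnc(O)nc1O`: 14100 nM
Compound 2 `Cc1ccc(C(=O)NNC(=O)c2cccc(NS(=O)(=O)c3cnc(O)nc3O)c2)cc1`: > 20000 nM, a limit of the assay and not a number

Among the compounds with values here, in a functional assay on OVCAR-3 cells (Homo sapiens) for antiproliferative activity, read by MTT assay, with a stated time of 24 h (on this read-out lower numbers stand for stronger inhibition and higher numbers for weaker inhibition), compound 1 gives 14100 nM, the only actual number so far. Compound 3 `O=C(NNC(=O)c1ccccc1NS(=O)(=O)c1cnc(O)nc1O)c1cccc(Cl)c1` differs from compound 1 by a single change: (3-chlorophenyl)carbonyl in place of 2-chlorophenyl on an amine nitrogen. In words, (3-chlorophenyl)carbonyl stands in place of 2-chlorophenyl on an amine nitrogen. Within the data shown here, no measured pair shows what this change does in this assay, so no shift beyond the usual scatter is expected. The expected step is a 1.1-fold higher number from compound 1 to compound 3 (0.05 log units; within the scatter). Compound 3 is estimated at 16000 nM, within an expected range of 7000 nM to 40000 nM.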

Compound 3, half-maximal inhibitory concentration: 2080 nM
Compound 3: the middle estimate sits 7.7-fold (0.89 log units) above what was measured; the whole stated range lies above it.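

In this assay, (3-chlorophenyl)carbonyl in place of 2-chlorophenyl on an amine nitrogen gives a 6.8-fold lower number from compound 1 to compound 3 (0.83 log units; beyond the scatter), so the potency responds clearly to the group at this position, something a single number could not show. The change adds a carbonyl and also moves the chlorine, so the step cannot be credited to either alone. Nothing shown here explains the step.

Still open, on these data alone, is what (2-chlorophenyl)carbonyl would give, since it keeps the chlorine where it was while adding the carbonyl. An unsubstituted benzoyl or a small acetyl at this position would show whether the chlorophenyl ring is needed at all.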